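This account rests on a few compounds, and the source may have more. Where it says the series, first, only, none or still open, it means among the compounds named here.

Measured so far:
compound 1, `N#Cc1cnc(NCc2ccccc2C(F)(F)F)cc1N[C@H]1CC[C@H](O)CC1`, giving 4000 nM in an assay on isolated protein for inhibition of protein kinase C theta type (Homo sapiens), read by TR-FRET, with a stated time of 2 h; a lower number here means a stronger inhibitor, a higher number a weaker inhibitor;
compound 2, `N#Cc1cnc(NCc2cncnc2C(F)(F)F)cc1N[C@H]1CC[C@@H](O)CC1`, giving 450 nM in this assay.

Of these two numbers, compound 2 holds the lower one, and the gap between compound 2 and compound 1 lies beyond the usual scatter of repeated measurements. The two compounds differ in more than one place, so what lies behind that gap cannot be told apart here.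

Compound 3, `N#Cc1cnc(NCc2cncnc2-c2ccccc2)cc1N[C@H]1CC[C@@H](O)CC1`, has not yet been measured in this assay. It differs from compound 2 in one place: phenyl in place of trifluoromethyl on an aromatic carbon. Within the data shown here, no measured pair shows this kind of exchange, so there is no direct guide for its size or direction. A change of this kind is expected to shift the number only moderately, with a small loss more likely than a gain. The expected step from compound 2 to compound 3 is a 1.6-fold higher number from compound 2 to compound 3 (0.19 log units; within the scatter). For compound 3 the estimate in this assay is 700 nM, with a range from 180 nM to 2800 nM.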

Compound 3, half-maximal inhibitory concentration: 90 nM
Compound 3: middle estimate off by 7.8-fold (0.89 log units), on the high side; measured number below the stated range.
By their numbers in this assay, from the lowest: compound 3; then compound 2; then compound 1.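

Among these compounds, putting phenyl in place of trifluoromethyl on this aromatic carbon, next to the ring nitrogen, gives a 5.0-fold lower number from compound 2 to compound 3 (0.70 log units; beyond the scatter) in this assay and is the first single exchange that can be read on its own. It shows that this position accepts a six-membered aromatic ring of carbon only, with more heavy atoms than the group it replaces, and that the number falls rather than rises. No measurement at hand bears on the reason for this step.

A single exchange cannot separate the part played by the aromatic ring from that of the larger count of heavy atoms. Going by these compounds, whether a cyclohexyl ring, a pyridine ring, a methyl group or an amine on this carbon would move the number the same way remains open.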